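From cycloheptyl to cyclohexyl on an oxygen

The source may hold more compounds than are shown below. What is called first, only, known or untested is meant among the compounds shown, and "the series" means these compounds.

Among the measured compounds shown here, only two compounds have so far been tested in a functional assay on KB 3-1 cells (Homo sapiens) for antiproliferative activity, read by MTT assay; on this read-out lower numbers stand for stronger inhibition and higher numbers for weaker inhibition. Compound 1 `CC(C)(C)[Si](O[C@H]1C[C@H]2CC(=O)C[C@H]2C1)(c1ccccc1)c1ccccc1` reached only a limit of the assay, > 40 ug/mL. For the measured compounds named here, compound 2 `CC(C)(C)[Si](OC1CCCCCC1)(c1ccccc1)c1ccccc1` gave 6.2 ug/mL, which is the sole true number available, so its standing cannot be judged against any other measured value. Going by the values given here, the one measured step is an at least 6.4-fold lower number from compound 1 to compound 2 (0.80 log units; beyond the scatter), and its size rests on (the limit of > 40 ug/mL in this assay, at which 1 of the 2 values shown sits).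

Compound 3 `CC(C)(C)[Si](OC1CCCCC1)(c1ccccc1)c1ccccc1` has not yet been measured. It differs from compound 2 by cyclohexyl in place of cycloheptyl on an oxygen, which is cyclohexyl in place of cycloheptyl on an oxygen. The measured step offers only limited guidance, since it involved a group with two rings and an oxygen, whereas cycloheptyl and cyclohexyl are each a single ring of carbon only, without hydrogen-bond donors or acceptors. Taking compound 2 at 6.2 ug/mL as the anchor, no change beyond the scatter is expected in this assay. The expected result is a 1.1-fold higher number from compound 2 to compound 3 (0.05 log units; within the scatter). Compound 3 is estimated at 7 ug/mL, with an expected range from 3 ug/mL to 16 ug/mL.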

Compound 3, half-maximal inhibitory concentration: 7.5 ug/mL
Beside the measured number, compound 3's estimate is 1.1-fold (0.03 log units) below it, and the stated range covers the measured number.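

Among the compounds shown here, on the oxygen whose other neighbour is silicon, cyclohexyl in place of cycloheptyl gives in this assay a 1.2-fold higher number from compound 2 to compound 3 (0.08 log units; within the scatter), so this is the first direct comparison of two single carbon-only rings at this place, and the read-out does not separate them. Compound 2 and compound 3 therefore stand together as a pair of single-ring compounds, and the activity seen with cycloheptyl is not confined to that one ring size. The second new step, an at least 5.3-fold lower number from compound 1 to compound 3 (0.72 log units; beyond the scatter), agrees with the earlier step from compound 1, but its size is bounded only by a limit: the limit of > 40 ug/mL in this assay, at which 1 of the 3 values shown sits.

The group on compound 1 differs from cyclohexyl in both its two five-membered rings and its oxygen, so the compounds shown cannot tell which of these features sets compound 1 apart from compound 3. Going by these compounds, it also remains open whether the read-out would hold with a smaller ring such as cyclopentyl, an open chain such as n-hexyl, or an amine or a hydroxyl carried on the cyclohexyl ring.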